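The source may hold more compounds than are shown below. What is called first, only, known or untested is meant among the compounds shown, and "the series" means these compounds.

Compound 1, `Cc1ccc(Nc2nnc(Nc3nc(-c4ccc(Cl)cc4)cs3)s2)cc1`, gives 300 mg/kg in a functional assay on the whole organism (strain albino) with Mus musculus as the target, in the maximal electroshock model, with a stated time of 0.5 h; on this read-out higher numbers stand for an effect only at larger amounts of compound and lower numbers for an effect already at smaller amounts.
Compound 2, `COc1ccc(Nc2nnc(Nc3nc(-c4ccc(Cl)cc4)cs3)s2)cc1`, gives 100 mg/kg in this assay.

Of these two numbers, compound 1 stands at the higher one; the nearest value is that of compound 2, with a 3.0-fold lower number from compound 1 to compound 2 (0.48 log units; beyond the scatter). Compound 3, `Cc1ccc(Nc2nnc(Nc3nc(-c4ccccc4)cs3)s2)cc1`, differs from compound 1 by hydrogen in place of chloro on an aromatic carbon. For the measured compounds named here, the one measured step, from compound 1 to compound 2, concerns the other end of the shared core, the methoxy in place of methyl on an aromatic carbon, and says nothing directly about removing the chloro. Going by the values given here, no measured pair shows the effect of this change, so the expectation rests on compound 1 alone. The step is therefore expected to be no change at the digits printed from compound 1 to compound 3 (within the scatter), with no direction beyond the scatter. Compound 3 is expected to give about 300 mg/kg, within a range from 100 mg/kg to 900 mg/kg.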

Compound 3, minimum effective dose: 100 mg/kg
Compound 3: middle estimate off by 3.0-fold (0.48 log units), on the high side; measured number inside the range.
By their numbers in this assay, from the lowest: compounds 2 and 3 (each within the scatter of the next); then compound 1.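

In this assay, the change from 4-chlorophenyl to phenyl gives a step beyond the scatter (a 3.0-fold lower number from compound 1 to compound 3 (0.48 log units; beyond the scatter)), so this position on the ring at the chloro end of the shared core affects the dose needed. Losing the chlorine does not cost activity here: the compound without it acts at the smaller dose. For the compounds shown here, until now, the only measured step lay at the other end of the shared core, so this is the first measured sign that the group at this position matters, and nothing available explains why the number moves in this direction.

Going by these compounds, at this position only chloro and hydrogen can be compared, so it remains open how a fluoro, an amine or a carboxylic acid would behave there. On these data alone, it is also open whether replacing chloro with hydrogen gives a similar step when methoxy stands in place of methyl.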